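Methylsulfonyl for ethyl on a benzamide mGlu5 antagonist

A few compounds are considered here, and "the series" means these few. Any claim that something is new, unique, unknown or untested is made for them only; others in the source may bear on it.

Measured so far:
- compound 1, `N#Cc1cc(F)cc(C(=O)Nc2cccc(F)c2)c1`: 2160 nM
- compound 2, `CCc1cccc(NC(=O)c2cc(F)cc(C#N)c2)c1`: 4940 nM

In an in vitro functional assay on HEK293-A cells for antagonist activity at metabotropic glutamate receptor 5 (Rattus norvegicus), read by calcium flux (a higher number here means a weaker inhibitor, a lower number a stronger inhibitor), compound 1 gives 2160 nM. Going by the values given here, compound 2 carries an ethyl group where compound 1 has fluoro, and in this assay compound 2 gives 4940 nM, the higher of the two numbers measured so far; the step of a 2.3-fold higher number from compound 1 to compound 2 (0.36 log units; beyond the scatter) separates it from compound 1. Compound 3, `CS(=O)(=O)c1cccc(NC(=O)c2cc(F)cc(C#N)c2)c1`, is not yet measured. It differs from compound 2 by methylsulfonyl in place of ethyl on an aromatic carbon. Among the compounds with values here, the only measured step that bears on this position is a 2.3-fold higher number from compound 1 to compound 2 (0.36 log units; beyond the scatter), where replacing fluoro by ethyl raised the number modestly. Nothing measured shows what a methylsulfonyl group does at this carbon, so the direction is uncertain, but a further modest rise beyond the scatter is expected, that is a 1.8-fold higher number from compound 2 to compound 3 (0.26 log units; within the scatter). Compound 3 is therefore estimated at 9000 nM, with a range from 3000 nM to 27000 nM.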

Compound 3, half-maximal inhibitory concentration: > 30000 nM
Compound 3: a limit, no number; the forecaster's own chance of this, stated with the estimate: 30%; at least 3.3-fold (0.52 log units) between middle value and limit.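

In this assay compound 3 gives > 30000 nM, which is a limit of the assay and not a number. Methylsulfonyl on this aromatic carbon gives an at least 6.0-fold higher number from compound 2 to compound 3 (0.78 log units; beyond the scatter), and against the fluoro group it gives an at least 13-fold higher number from compound 1 to compound 3 (1.14 log units; beyond the scatter), so the numbers rise in the order fluoro, ethyl, methylsulfonyl, and this position proves far less forgiving than the earlier modest step alone suggested. Both new steps are only bounds, and their true size remains unknown: the limit of > 30000 nM in this assay, at which 1 of the 3 values shown sits.

The three compounds cannot separate the added heavy atoms from the hydrogen-bond acceptors that methylsulfonyl brings, as the two enter together. As far as these compounds go, what an amine, a carboxylic acid or a methoxy group would do on this carbon stays open.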